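Clearance notes: the 3-propoxyphenyl step from compound 2

The source may report more compounds than this note shows. Statements on the series, on what has been measured and on what is new or still open speak of the compounds shown alone.

compound 1 `CC(C)(CO)CNC(=O)c1cc2cc(C#N)ccc2n1Cc1cccc(OC(F)(F)F)c1` gives 20 mL.min-1.g-1 in an in vitro ADME assay on microsomes from liver (Homo sapiens) for metabolic stability, in the presence of a further agent that is not named here; on this read-out lower numbers stand for slow clearance and higher numbers for fast clearance
compound 2 `Cc1ccc(C)c(Cn2c(C(=O)NCC(C)(C)CO)cc3cc(C#N)ccc32)c1` gives 29 mL.min-1.g-1 in this assay

Compound 2 and compound 1 lie within the scatter of each other, so compound 2 does not stand apart on these numbers. Compound 3 `CCCOc1cccc(Cn2c(C(=O)NCC(C)(C)CO)cc3cc(C#N)ccc32)c1` differs from compound 2 by 3-propoxyphenyl in place of 2,5-dimethylphenyl on a saturated chain carbon bound to an aromatic nitrogen on a saturated chain carbon bound to an aromatic nitrogen. Among the measured compounds shown here, no measured step covers this change. A modest rise in this assay is expected, estimated as a 1.4-fold higher number from compound 2 to compound 3 (0.14 log units; within the scatter) and not far beyond the scatter. Compound 3 is estimated at 40 mL.min-1.g-1 with an expected range from 18 mL.min-1.g-1 to 85 mL.min-1.g-1 as plausible.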

Compound 3, intrinsic clearance in microsomes: 10 mL.min-1.g-1
The estimate for compound 3 lay 4.0-fold (0.60 log units) above the measured number; measured number below the stated range.
By their numbers in this assay, from the lowest: compounds 3, 1 and 2 (each within the scatter of the next, the first and the last beyond it).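

In this assay, the place on a saturated chain carbon bound to an aromatic nitrogen now shows a step beyond the scatter: 3-propoxyphenyl in place of 2,5-dimethylphenyl gives a 2.9-fold lower number from compound 2 to compound 3 (0.46 log units; beyond the scatter) in this series. Propyl in place of trifluoromethyl on an oxygen on an aromatic ring gives a 2.0-fold lower number from compound 1 to compound 3 (0.30 log units; within the scatter) and does not separate these two compounds. No measurement shown offers a reason for either step.

The compounds shown leave open how the step from compound 2 divides between the oxygen and the propyl chain. Also open, as far as these compounds go, is how a butyl chain or an amine on that oxygen would read in this assay.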